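This account rests on a few compounds, and the source may have more. Where it says the series, first, only, none or still open, it means among the compounds named here.

In a functional assay on HL-60 cells (Homo sapiens) for antiproliferative activity, read by MTT assay (on this read-out lower numbers stand for stronger inhibition and higher numbers for weaker inhibition), compound 1 (`O[C@@H]1[C@@H](OCc2ccccc2)[C@H](OCc2ccccc2)[C@@H](COCc2ccccc2)O[C@H]1CC1CCCCC1`) gives 4100 nM and compound 3 (`O[C@@H]1[C@@H](OCc2ccccc2)[C@H](OCc2ccccc2)[C@@H](COCc2ccccc2)O[C@H]1Cc1ccccc1`) gives 8700 nM as the higher of the two numbers in hand. Compound 2 (`C#CC[C@@H]1O[C@H](COCc2ccccc2)[C@@H](OCc2ccccc2)[C@H](OCc2ccccc2)[C@H]1O`) is recorded as "not active" (no number reported) with no number, so it cannot be ranked. Compound 4 (`O[C@@H]1[C@@H](OCc2ccccc2)[C@H](OCc2ccccc2)[C@@H](COCc2ccccc2)O[C@H]1c1ccccc1`) is still unmeasured and differs from compound 3 by phenyl in place of benzyl on a saturated ring carbon, next to the ring oxygen (phenyl in place of benzyl on a saturated ring carbon).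

Among the compounds with values here, only one measured step bears on this, and only loosely: a 2.1-fold higher number from compound 1 to compound 3 (0.33 log units; beyond the scatter) is modest and exchanges cyclohexyl for phenyl, which is a different change. Within the data shown here, no measured pair shows the effect of phenyl in place of benzyl, so no direction can be assigned and no step beyond the scatter is expected in this assay. The estimated step of a 1.0-fold higher number from compound 3 to compound 4 (0.01 log units; within the scatter) is therefore small. For compound 4 the expected value is 9000 nM with an estimated range of 3500 nM to 25000 nM given the thin evidence.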

Compound 4, half-maximal inhibitory concentration: 26300 nM
Compound 4: the middle estimate sits 2.9-fold (0.47 log units) below what was measured; measured number above the stated range.
By their numbers in this assay, from the lowest: compound 1; then compound 3; then compound 4.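

At the saturated ring carbon next to the ring oxygen, the read-out in this assay depends on the link to the aromatic ring as well as on the ring itself: taking benzyl to phenyl gives a 3.0-fold higher number from compound 3 to compound 4 (0.48 log units; beyond the scatter). Across the full replacement of cyclohexylmethyl by phenyl, the series shows a 6.4-fold higher number from compound 1 to compound 4 (0.81 log units; beyond the scatter), so the numbers rise in order from cyclohexylmethyl through benzyl to phenyl, while compound 2 has no number and cannot be placed in that order. No supporting data are available to explain this rise.

On these data alone, it remains open whether a cyclohexyl bound directly to this ring carbon would follow the same course as phenyl. Also open, as far as these compounds go, is how a longer chain such as 2-phenylethyl, or an aminomethyl group, would fit this order.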